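A few compounds are considered here, and "the series" means these few. Any claim that something is new, unique, unknown or untested is made for them only; others in the source may bear on it.

Measured so far: compound 1 `O=C(OC1(C(=O)Nc2ccc([N+](=O)[O-])cc2)CCCCC1)c1ccc(C(F)(F)F)cc1`, compound 2 `Cc1ccc(C(=O)OC2(C(=O)Nc3ccc([N+](=O)[O-])cc3)CCCCC2)cc1` and compound 3 `Cc1ccccc1C(=O)OC1(C(=O)Nc2ccc([N+](=O)[O-])cc2)CCCCC1`.

In an ADME assay on WI-38 cells (Homo sapiens) for inhibition, read by MTT assay, with a stated time of 72 h (on this read-out lower numbers stand for stronger inhibition and higher numbers for weaker inhibition), compound 1 gives 185 nM. Compound 2 gives 32 nM, and compound 3 gives 352 nM, the highest number of the three. The steps into it read a 1.9-fold higher number from compound 1 to compound 3 (0.28 log units; within the scatter) and an 11-fold higher number from compound 2 to compound 3 (1.04 log units; beyond the scatter); the first lies within the scatter, the second beyond it.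

Compound 4 `O=C(OC1(C(=O)Nc2ccc([N+](=O)[O-])cc2)CCCCC1)c1ccc(Br)cc1` differs from compound 3 in one place: 4-bromophenyl in place of 2-methylphenyl on a carbonyl carbon. The two steps into compound 3 bear on this change, since both start from a 4-substituted phenyl ester and both show compound 3 with the higher number. Read in reverse, they point to a lower number for compound 4, somewhere between within the scatter and large. Compound 4 is therefore expected to show a 3.5-fold lower number from compound 3 to compound 4 (0.55 log units; beyond the scatter). The estimate for compound 4 is 100 nM, with a range from 30 nM to 400 nM.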

Compound 4, half-maximal inhibitory concentration: 523 nM
Compound 4: middle estimate off by 5.2-fold (0.72 log units), on the low side; measured number above the stated range.
By their numbers in this assay, from the lowest: compound 2; then compounds 1, 3 and 4 (each within the scatter of the next, the first and the last beyond it).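

In this assay, exchanging 2-methylphenyl for 4-bromophenyl on a carbonyl carbon does not move the number beyond the scatter (a 1.5-fold higher number from compound 3 to compound 4 (0.17 log units; within the scatter)). The 4-phenyl ester form alone therefore does not bring the low number of compound 2, since bromo in place of methyl is a large step (a 16-fold higher number from compound 2 to compound 4 (1.21 log units; beyond the scatter)) and bromo in place of trifluoromethyl a modest one (a 2.8-fold higher number from compound 1 to compound 4 (0.45 log units; beyond the scatter)). No supporting measurement here explains these differences.

On these data alone, it remains open whether an amine or a carboxylic acid in place of the bromo would approach compound 2. Also open, as far as these compounds go, is whether a longer chain, such as ethyl in place of its methyl, would hold that low number.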